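A few compounds are considered here, and "the series" means these few. Any claim that something is new, unique, unknown or untested is made for them only; others in the source may bear on it.

Measured so far in a functional assay with Oryctolagus cuniculus as the target; a lower number here means a stronger inhibitor, a higher number a weaker inhibitor:
compound 1 `COc1ccc(-c2nc(/N=C(\N)NC3CCCCC3)sc2-c2ccc(OC)cc2)cc1` — > 1000 nM
compound 2 `COc1ccc(-c2nc(C(N)=O)sc2-c2ccc(OC)cc2)cc1` — > 1000 nM

Both measured values in this assay are limits of the assay, not numbers. Compound 1 gives only the limit > 1000 nM in this assay. Compound 2 likewise gives only the limit > 1000 nM in this assay. Among the measured compounds shown here, compound 2 therefore stands at the limit, and the only other value shown sits there too: the limit of > 1000 nM in this assay, at which 2 of the 2 values shown sit. For the measured compounds named here, the one measured step, a step that the two limits leave unreadable from compound 1 to compound 2, has no readable size.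

Compound 3 `COc1ccc(-c2nc(C3=NNC(=O)CC3)sc2-c2ccc(OC)cc2)cc1` is the next change on this core: a group of 7 heavy atoms (4 carbon, 2 nitrogen, 1 oxygen; one six-membered non-aromatic ring with 2 hetero atoms) in place of a group of 3 heavy atoms (1 carbon, 1 nitrogen, 1 oxygen; no ring), on an aromatic carbon

Going by the values given here, no measured step bears readably on this change, since both ends of the only step are limits. With compound 2 at the limit, no movement beyond the scatter can be foreseen, and the step is expected to be a step that the limit leaves unreadable from compound 2 to compound 3. Compound 3 is estimated at 3000 nM, in the range 800 nM to 20000 nM, most likely reported again only as a limit in this assay.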

Compound 3, half-maximal inhibitory concentration: > 1000 nM
Compound 3 was reported as a limit; the forecaster's own chance of this, stated with the estimate: 75%; the middle value is on the limit's open side.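

In this assay compound 3 gives only a limit, > 1000 nM. The steps to compound 3 from compound 1 and from compound 2 therefore cannot be read: the limit of > 1000 nM in this assay, at which 3 of the 3 values shown sit.

The compounds shown leave open whether any group at this place on the shared core gives a measurable value in this assay.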